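A few compounds are considered here, and "the series" means these few. Any claim that something is new, unique, unknown or untested is made for them only; others in the source may bear on it.

Measured in an ADME assay on MDCKII-LE cells (Canis lupus familiaris) for permeability; a lower number here means that the compound crosses the layer more slowly, a higher number that the compound crosses the layer faster:
- compound 1 `COc1ccc(S(N)(=O)=O)cc1C(=O)Nc1cccc(-c2nncn2C(C)C)n1`: 2 10^-6 cm/s
- compound 2 `COc1cc(C)c(S(N)(=O)=O)cc1C(=O)Nc1cccc(-c2nncn2C(C)C)n1`: 2.3 10^-6 cm/s
- compound 3 `CCS(=O)(=O)Nc1ccc(OC)c(C(=O)Nc2cccc(-c3nncn3C(C)C)n2)c1`: 5.6 10^-6 cm/s

Compound 2, at 2.3 10^-6 cm/s, is second highest of the three numbers, within the scatter of compound 1 and below compound 3. The next structure is compound 4 `COc1cc(C)c(S(C)(=O)=O)cc1C(=O)Nc1cccc(-c2nncn2C(C)C)n1`: methyl in place of amino on a sulfonyl sulfur, or sulfamoyl to methylsulfonyl. Among the measured compounds shown here, no measured step makes this exact change. The closest is a 2.8-fold higher number from compound 1 to compound 3 (0.45 log units; beyond the scatter), a modest step in which sulfamoyl also leaves. The other step, a 1.2-fold higher number from compound 1 to compound 2 (0.06 log units; within the scatter), adds only the aromatic methyl and offers little guidance. Taken from the closer step, the estimated change in this assay is upward, a 2.2-fold higher number from compound 2 to compound 4 (0.34 log units; beyond the scatter). The estimated value for compound 4 is 5 10^-6 cm/s, with an expected range from 2.5 10^-6 cm/s to 11 10^-6 cm/s.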

Compound 4, apparent permeability: 7.2 10^-6 cm/s
The estimate for compound 4 lay 1.4-fold (0.16 log units) below the measured number, and the stated range covers the measured number.
By their numbers in this assay, from the lowest: compounds 1 and 2 (each within the scatter of the next); then compounds 3 and 4 (each within the scatter of the next).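

Methyl in place of amino on a sulfonyl sulfur gives the first direct reading of sulfamoyl to methylsulfonyl in this assay, a 3.1-fold higher number from compound 2 to compound 4 (0.50 log units; beyond the scatter), with the aromatic methyl kept in both compounds. The earlier sulfamoyl step, to (ethylsulfonyl)amino, involved a different incoming group. No available evidence explains this step. Open, from the compounds shown here alone, are whether a longer chain such as ethyl or propyl on the sulfonyl sulfur, or a dimethylamino group there, reads the same way, and whether the step holds without the aromatic methyl.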